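Swapping the nitrile for a sulfonamide on the shared core

This account rests on a few compounds, and the source may have more. Where it says the series, first, only, none or still open, it means among the compounds named here.

Compound 1 `O=C(O)Cc1sc(C(c2ccc(F)cc2)c2ccc(F)cc2)nc1-c1ccc(Cl)cc1` gives 180 nM in an in vitro functional assay on HEK285-7 cells for antagonist activity at prostaglandin D2 receptor 2 (Homo sapiens), read by BRET and beta-arrestin recruitment; on this read-out lower numbers stand for stronger inhibition and higher numbers for weaker inhibition.
Compound 2 `O=C(O)Cc1sc(C(c2ccc(F)cc2)c2ccc(F)cc2)nc1-c1cccc(F)c1` gives 18 nM in this assay.
Compound 3 `N#Cc1ccc(-c2nc(C(c3ccc(F)cc3)c3ccc(F)cc3)sc2CC(=O)O)cc1` gives 1500 nM in this assay.

Three compounds share one core and differ only in the group on the aryl ring attached to it. Compound 3 carries the highest number of the three: an 8.3-fold higher number from compound 1 to compound 3 (0.92 log units; beyond the scatter), and an 83-fold higher number from compound 2 to compound 3 (1.92 log units; beyond the scatter). Compound 4 `NS(=O)(=O)c1ccc(-c2nc(C(c3ccc(F)cc3)c3ccc(F)cc3)sc2CC(=O)O)cc1` keeps everything else and makes one change: sulfamoyl in place of cyano on an aromatic carbon.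

Within the data shown here, no measured pair shows this exact exchange, so the expectation rests on the neighbouring steps. Among the measured compounds shown here, the only step that touches the same position is the one from compound 1 to compound 3, a modest worsening when chloro became cyano, and the steps to compound 2 show that this position is sensitive. The sulfamoyl group is a further departure from both chloro and cyano, so a step of modest size in either direction is plausible, with no clear pull one way.

Compound 4 is therefore estimated at 2000 nM in this assay, with a likely range from 500 nM to 8000 nM. This estimate means a step of a 1.3-fold higher number from compound 3 to compound 4 (0.12 log units; within the scatter), expected to be small relative to what was seen before.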

Compound 4, half-maximal inhibitory concentration: > 100000 nM
Compound 4 gave a limit, no number (the forecaster's own chance of this, stated with the estimate: 15%); middle value at least 50-fold (1.69 log units) away from the limit.
By their numbers in this assay, from the lowest: compound 2; then compound 1; then compound 3. At a limit, above all of these: compound 4.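

Compound 4 gives a limit of the assay, not a number: the limit of > 100000 nM in this assay, at which 1 of the 4 values shown sits.

Even as a limit, this exchange is a large step, an at least 66-fold higher number from compound 3 to compound 4 (1.82 log units; beyond the scatter), and it exceeds the modest worsening seen when cyano replaced chloro at this same place, an 8.3-fold higher number from compound 1 to compound 3 (0.92 log units; beyond the scatter). Against the other two compounds the result reads an at least 550-fold higher number from compound 1 to compound 4 (2.74 log units; beyond the scatter) for sulfamoyl in place of chloro and an at least 5500-fold higher number from compound 2 to compound 4 (3.74 log units; beyond the scatter) for 4-sulfamoylphenyl in place of 3-fluorophenyl, so the earlier compounds, which all gave numbers, showed only part of how much this place on the aryl ring, para to a large group, can shift the read-out.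

The compounds shown cannot tell which part of the sulfamoyl group matters, the nitrogen with its hydrogens or the sulfur with its two oxygens. They also leave open how a methylsulfonyl group, an amine or a carboxylic acid on this same aromatic carbon would read, and whether sulfamoyl would give a similar step where compound 2 carries its fluoro group.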